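From 4-Methoxyphenyl to 3-Chlorophenyl in Compound 3

This account rests on a few compounds, and the source may have more. Where it says the series, first, only, none or still open, it means among the compounds named here.

- compound 1 `Cc1ccc2nc(NC(c3cn(-c4ccccc4)nc3-c3cccc(Cl)c3)c3c(O)ccc4ccccc34)sc2c1`: 9430 nM
- compound 2 `COc1ccc(-c2nn(-c3ccccc3)cc2C(Nc2nc3ccccc3s2)c2c(O)ccc3ccccc23)cc1`: 9340 nM

Both values come from a functional assay on HeLa cells (Homo sapiens) for antiproliferative activity, read by MTT assay, with a stated time of 48 h; a lower number here means a stronger inhibitor, a higher number a weaker inhibitor. Compound 2 stands level with compound 1, since the gap between their values lies within the scatter of repeated measurements, so neither can be ranked above the other.

Compound 3 `Oc1ccc2ccccc2c1C(Nc1nc2ccccc2s1)c1cn(-c2ccccc2)nc1-c1cccc(Cl)c1` has not yet been measured. It is compound 2 with 3-chlorophenyl in place of 4-methoxyphenyl on an aromatic carbon. Among the measured compounds shown here, no measured pair here isolates this kind of change, so the data offer no direct guide to its effect. With compound 1 at 9430 nM and compound 2 at 9340 nM, the only available anchor is this shared level. The estimated step of a 1.0-fold lower number from compound 2 to compound 3 (0.02 log units; within the scatter) is therefore expected to stay within the scatter, with no clear direction. For compound 3 the expected value is 9000 nM, with an estimated range of 4000 nM to 20000 nM.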

Compound 3, half-maximal inhibitory concentration: 6830 nM
Estimate against measurement, compound 3: 1.3-fold (0.12 log units) above; the range from low to high includes it.
By their numbers in this assay, from the lowest: compounds 3, 2 and 1 (each within the scatter of the next).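

In this assay, among the compounds shown here, 3-chlorophenyl in place of 4-methoxyphenyl on this carbon of the five-membered ring gives a first direct reading of this change (a 1.4-fold lower number from compound 2 to compound 3 (0.14 log units; within the scatter)), and the number does not shift beyond the scatter despite the loss of the methoxy oxygen. The same compound 3 also allows a second comparison, hydrogen in place of methyl on an aromatic carbon (a 1.4-fold lower number from compound 1 to compound 3 (0.14 log units; within the scatter)), and this step likewise stays within the scatter. Nothing available explains why either change leaves the number so little altered.

Going by these compounds, each change is read only once, so it remains open whether the same holds on other versions of the shared core. On these data alone, it is also open whether a phenyl ring carrying an amine or a carboxylic acid at this position would move the number beyond the scatter.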